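A Double Bond Removed from the Chain

A few compounds are considered here, and "the series" means these few. Any claim that something is new, unique, unknown or untested is made for them only; others in the source may bear on it.

For the measured compounds named here, in an ADME assay on CHO-K1 cells (Cricetulus griseus) for cytotoxicity, read by MTT assay, with a stated time of 24 h (on this read-out lower numbers stand for stronger inhibition and higher numbers for weaker inhibition), compound 1 `CCCCCCCC/C=C\CCCCCCCC(=O)Nc1nnc(S[C@@H]2O[C@H](COC(C)=O)[C@H](OC(C)=O)[C@H](OC(C)=O)[C@H]2OC(C)=O)s1` gives 26300 nM, the only number available so far. Compound 2 `CCCCCCCCCCCCCCCC(=O)Nc1nnc(S[C@@H]2O[C@H](CO)[C@H](O)[C@H](O)[C@H]2O)s1` is recorded as "not active" (no number reported). Compound 3 `CCCCCCCCCCCCCC(=O)Nc1nnc(S[C@@H]2O[C@H](CO)[C@H](O)[C@H](O)[C@H]2O)s1` is likewise recorded as "not active" (no number reported). With a single number, compound 1 cannot be placed on any numerical scale against these two. Compound 4 `CCCCCCCCCCCCCCCC(=O)Nc1nnc(S[C@@H]2O[C@H](COC(C)=O)[C@H](OC(C)=O)[C@H](OC(C)=O)[C@H]2OC(C)=O)s1` is still unmeasured and keeps the core of compound 1, changing only the chain: octyl in place of dec-1-en-1-yl on a saturated chain carbon, seven bonds along the chain from a carbonyl carbon. Going by the values given here, no measured pair shows this change alone, so the expected step in this assay is none beyond the usual scatter, in either direction. The estimated value for compound 4 is 30000 nM, with a range from 12000 nM to 80000 nM.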

Compound 4, half-maximal inhibitory concentration: 90400 nM
For compound 4 the middle estimate is 3.0-fold (0.48 log units) below the measured one, and the stated range ends below it.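

In this assay, putting octyl in place of dec-1-en-1-yl on a saturated chain carbon, seven bonds along the chain from a carbonyl carbon, gives a 3.4-fold higher number from compound 1 to compound 4 (0.54 log units; beyond the scatter). With the rest of compound 1 unchanged, this shows that the chain alone can shift the result toward weaker inhibition. No measurement shown explains the shift.

This one change removes the double bond and shortens the group together, and the compounds shown do not separate those two differences. On these data alone, how a longer saturated chain or a carboxylic acid at this place would read remains open.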